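The source may report more compounds than this note shows. Statements on the series, on what has been measured and on what is new or still open speak of the compounds shown alone.

Compound 2 `CCOC(=O)c1c(-c2c(Cl)c3ccccc3oc2=O)nn(-c2cccc(C)c2)c1C(=O)OCC` gives the lowest of the two numbers measured in a functional assay on HeLa cells (Homo sapiens) for cytotoxicity, read by MTT assay, with a stated time of 48 h (a lower number here means a stronger inhibitor, a higher number a weaker inhibitor), namely 30000 nM. For the measured compounds named here, the only neighbour is compound 1 `CCOC(=O)c1c(-c2c(Cl)c3ccccc3oc2=O)nn(-c2ccccc2)c1C(=O)OCC`, which in this assay gives 100000 nM. Going by the values given here, the single step between them, a 3.3-fold lower number from compound 1 to compound 2 (0.52 log units; beyond the scatter), is the one piece of evidence on how a change on the aryl group attached to the ring nitrogen affects the read-out. Compound 3 `CCOC(=O)c1c(-c2c(Cl)c3ccccc3oc2=O)nn(-c2ccc(OC)cc2)c1C(=O)OCC` differs from compound 2 in one place: 4-methoxyphenyl in place of 3-methylphenyl on an aromatic nitrogen. Among the compounds with values here, that change removes the methyl whose introduction produced the step from compound 1 to compound 2 and brings in a methoxy group instead, so no measured step bears on it directly. Compound 3 is therefore expected to land between the two measured numbers, with the step of a 1.3-fold higher number from compound 2 to compound 3 (0.12 log units; within the scatter) estimated to be small, toward a slightly higher number. The estimate for compound 3 in this assay is 40000 nM, with a range from 10000 nM to 100000 nM.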

Compound 3, half-maximal inhibitory concentration: 27000 nM
For compound 3 the middle estimate is 1.5-fold (0.17 log units) above the measured one, within the range that was stated.
By their numbers in this assay, from the lowest: compounds 3 and 2 (each within the scatter of the next); then compound 1.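

With a methoxy group taking the place of a hydrogen, a 3.7-fold lower number from compound 1 to compound 3 (0.57 log units; beyond the scatter) in this assay, so the gain on the aryl group attached to the ring nitrogen is no longer seen with methyl alone. Exchanging 3-methylphenyl for 4-methoxyphenyl gives a 1.1-fold lower number from compound 2 to compound 3 (0.05 log units; within the scatter), so these two groups cannot be told apart here, even though both the substituent and its ring position differ. Nothing available explains these steps.

The compounds shown leave open how far each substituent's ring position matters, since 3-methylphenyl and 4-methoxyphenyl each show one substituent at one position only. They also leave open whether an amine, a carboxylic acid or a longer alkoxy chain on the same phenyl ring would move the number further.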